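This account rests on a few compounds, and the source may have more. Where it says the series, first, only, none or still open, it means among the compounds named here.

Measured so far:
compound 1 `CS(=O)(=O)c1ccc(Cc2n[nH]c(=S)n2/N=C/c2ccccc2F)cc1` – 21.9%
compound 2 `CS(=O)(=O)c1ccc(Cc2n[nH]c(=S)n2/N=C/c2cccnc2)cc1` – 14%

In a functional assay on HeLa cells (Homo sapiens) for cytotoxicity, read by MTT assay, with a stated time of 48 h, tested at 50 uM (a lower number here means a weaker effect, a higher number a stronger effect of the compound at the concentration tested), compound 1 gives 21.9%, and compound 2 gives 14%. Among the measured compounds shown here, the one step between them, a number 7.9 percentage points lower from compound 1 to compound 2 (within the scatter), lies within the scatter, so the two compounds cannot be ordered; compound 2 holds the lower of the two numbers but is not weaker beyond the scatter. Compound 3 `CS(=O)(=O)c1ccc(Cc2n[nH]c(=S)n2/N=C/c2cccs2)cc1` is not yet measured. It differs from compound 2 by thiophen-2-yl in place of pyridin-3-yl on a carbon with a double bond to nitrogen. For the measured compounds named here, the only step that bears on this change is a number 7.9 percentage points lower from compound 1 to compound 2 (within the scatter), which swapped one aromatic ring for another at the same carbon and stayed within the scatter. On that basis the step to compound 3 is expected to be small, with no direction resolved beyond the scatter: a number 3 percentage points higher from compound 2 to compound 3 (within the scatter). The estimate for compound 3 in this assay is 17%, with a range from 5% to 32%.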

Compound 3, a percentage reported as activity, at one concentration (the size of the read-out at that concentration, not a potency): 48.6%
Estimate against measurement, compound 3: 31.6 percentage points below; the whole stated range lies below it.
By their numbers in this assay, from the lowest: compounds 2 and 1 (each within the scatter of the next); then compound 3.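

In this assay, the position on the carbon with a double bond to nitrogen proves responsive to the ring placed there: thiophen-2-yl gives a number 34.6 percentage points higher from compound 2 to compound 3 (beyond the scatter) and a number 26.7 percentage points higher from compound 1 to compound 3 (beyond the scatter). The earlier swap between aromatic rings, a number 7.9 percentage points lower from compound 1 to compound 2 (within the scatter), did not separate its two compounds, so the five-membered sulfur ring is the only one of the three that stands apart, and not every ring exchange here is silent. Nothing at hand accounts for this rise.

Going by these compounds, whether the gain belongs to thiophen-2-yl alone remains open, as furan-2-yl, thiophen-3-yl or a plain phenyl could show whether it extends to related rings. Also open, on these data alone, is how a ring carrying an amine or a carboxylic acid would read at this position, and all three values remain single-concentration read-outs, not potencies.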